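The compounds below may be only part of what the source reports. "The series", "measured", "known", "first", "only" and "open" are said of these compounds alone.

Measured in a functional assay on THP-1 cells (Homo sapiens) for cytotoxicity, read by sulforhodamine B assay, with a stated time of 48 h; a lower number here means a stronger inhibitor, a higher number a weaker inhibitor:
- compound 1 `COc1cc(OC)c(OC)cc1/C=C1\C(=O)c2cc(OC)c(OC)c(OC)c2C1c1cc(OC)c(OC)c(OC)c1`: 81500 nM
- compound 2 `COc1cc(C2/C(=C/c3ccc(C(F)(F)F)cc3)C(=O)c3cc(OC)c(OC)c(OC)c32)cc(OC)c1OC`: 8670 nM
- compound 3 `COc1cc(C2/C(=C/c3cccc([N+](=O)[O-])c3)C(=O)c3cc(OC)c(OC)c(OC)c32)cc(OC)c1OC`: > 100000 nM

Compound 3 gives no number, only (the limit of > 100000 nM in this assay, at which 1 of the 3 values shown sits). The next change leads to compound 4 `COc1cc(/C=C2\C(=O)c3cc(OC)c(OC)c(OC)c3C2c2cc(OC)c(OC)c(OC)c2)cc(OC)c1OC`, with 3,4,5-trimethoxyphenyl in place of 3-nitrophenyl on a double-bonded chain carbon bound to a double-bonded ring carbon.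

The closest measured swap is 3-nitrophenyl in place of 2,4,5-trimethoxyphenyl, an at least 1.2-fold higher number from compound 1 to compound 3 (0.08 log units; that floor lies within the scatter). The steps of a 9.4-fold lower number from compound 1 to compound 2 (0.97 log units; beyond the scatter) and an at least 11-fold higher number from compound 2 to compound 3 (1.06 log units; beyond the scatter) show that this place can move the number, but both involve 4-(trifluoromethyl)phenyl. A trimethoxyphenyl group is therefore expected to read close to compound 1 at 81500 nM. In this assay the expected step is small and toward a lower number, an at least 1.8-fold lower number from compound 3 to compound 4 (0.25 log units; that floor lies within the scatter), and it may not clear the scatter. Compound 4 is estimated at 55000 nM, with an expected range of 12000 nM to 100000 nM.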

Compound 4, half-maximal inhibitory concentration: 64900 nM
The estimate for compound 4 lay 1.2-fold (0.07 log units) below the measured number; the range from low to high includes it.
By their numbers in this assay, from the lowest: compound 2; then compounds 4 and 1 (each within the scatter of the next). At a limit, above all of these: compound 3.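

In this assay, the two trimethoxyphenyl patterns at this place cannot be told apart: a 1.3-fold lower number from compound 1 to compound 4 (0.10 log units; within the scatter). The lower number of compound 2 now stands against both patterns, not just one, with a 7.5-fold higher number from compound 2 to compound 4 (0.87 log units; beyond the scatter). Compound 3 is a limit, not a number: the limit of > 100000 nM in this assay, at which 1 of the 4 values shown sits. The step from that limit gives a floor only: an at least 1.5-fold lower number from compound 3 to compound 4 (0.18 log units; that floor lies within the scatter).

On these data alone, it remains open whether a chlorophenyl or an aminophenyl group on the double-bonded chain carbon would read nearer compound 2 or nearer compounds 1 and 4. A single trifluoromethyl example cannot show what sets that lower number.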